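A few compounds are considered here, and "the series" means these few. Any claim that something is new, unique, unknown or untested is made for them only; others in the source may bear on it.

The study concerns two compounds already measured and one still to be tested. Compound 1, with the structure `FC(F)(F)c1ccccc1-c1nc(NCc2ccc(-c3ccccc3)cc2)c2ccccc2n1`, gives 3700 nM in an assay on a protein complex for inhibition of ubiquitin carboxyl-terminal hydrolase 1/WD repeat-containing protein 48 (Homo sapiens), read by fluorescence; on this read-out lower numbers stand for stronger inhibition and higher numbers for weaker inhibition. Compound 2, with the structure `FC(F)(F)c1ccc(-c2nc(NCc3ccc(-c4cccnc4)cc3)c3ccccc3n2)cc1`, is recorded in this assay as "not active" (no number reported), so no number stands for it and it can only be placed as the weaker of the two measured compounds, without any size being put on that gap.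

Compound 3 has the structure `CCc1ccccc1-c1nc(NCc2ccc(-c3cccnc3)cc2)c2ccccc2n1`. Relative to compound 2 the change is 2-ethylphenyl in place of 4-(trifluoromethyl)phenyl on an aromatic carbon. This is the single structural move followed here; nothing else in the molecule is altered.

Among the compounds with values here, no measured pair shows this exact exchange, so the expected size of the step in this assay has to be guessed. Since compound 2 gives no number, the step can only be one toward a measurable value, and the sole anchor for where such a value might lie is compound 1 at 3700 nM. On that basis compound 3 is expected to return a weak but recordable result of about 5000 nM, within a range from 1500 nM to 20000 nM.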

Compound 3, half-maximal inhibitory concentration: 780 nM
Compound 3: middle estimate off by 6.4-fold (0.81 log units), on the high side, outside the stated range (below it).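

Compound 2 has no number in this assay and compound 3 gives 780 nM, so no step can be read between them. The compounds shown leave open how large the effect of exchanging 4-(trifluoromethyl)phenyl for 2-ethylphenyl is on this read-out. Nothing shown offers an explanation for the value of compound 3.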